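The compounds below may be only part of what the source reports. "The series", "measured", "known", "first", "only" and "open" are said of these compounds alone.

Three ureas built on the shared core of compound 1 have been run so far. In a functional assay on HUVEC cells (Homo sapiens) for antiproliferative activity, read by sulforhodamine B assay, with a stated time of 48 h (on this read-out lower numbers stand for stronger inhibition and higher numbers for weaker inhibition), compound 1 `CN1CCC(COc2ccc3c(Nc4ccc(NC(=O)Nc5cccc(F)c5)c(Cl)c4)ncnc3c2)CC1` gives 132 nM, compound 2 `Cc1ccc(NC(=O)Nc2ccc(Nc3ncnc4cc(OCC5CCN(C)CC5)ccc34)cc2)cc1Br` gives 196 nM and compound 3 `COc1cc2c(Nc3ccc(NC(=O)Nc4cccc(F)c4)c(F)c3)ncnc2cc1OCC1CCN(C)CC1` gives 185 nM; the gaps between compound 2 and each of the other two are within the scatter, so the three numbers are not separable on this read-out. Compound 4 `CN1CCC(COc2ccc3c(Nc4ccc(NC(=O)Nc5ccc(Cl)c(C(F)(F)F)c5)cc4)ncnc3c2)CC1` has not been measured yet. It differs from compound 2 in one place: 4-chloro-3-(trifluoromethyl)phenyl in place of 3-bromo-4-methylphenyl on an amide-type nitrogen. Going by the values given here, no measured pair shows this exchange, so nothing fixes its size; the expected step of a 1.6-fold lower number from compound 2 to compound 4 (0.21 log units; within the scatter) is small, towards a lower number at most by a margin near the scatter. Compound 4 is estimated at 120 nM, between 40 nM and 400 nM.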

Compound 4, half-maximal inhibitory concentration: 92 nM
Estimate against measurement, compound 4: 1.3-fold (0.12 log units) above; the range from low to high includes it.
By their numbers in this assay, from the lowest: compounds 4, 1, 3 and 2 (each within the scatter of the next, the first and the last beyond it).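

In this assay, going by these compounds alone, the exchange of 3-bromo-4-methylphenyl for 4-chloro-3-(trifluoromethyl)phenyl on the amide-type nitrogen gives the first readable single-place step: a 2.1-fold lower number from compound 2 to compound 4 (0.33 log units; beyond the scatter) is modest but beyond the scatter. This position therefore accepts a group of 11 heavy atoms in place of one of 8 with no loss of inhibition. No data on hand explain the step.

The separate contributions of the chlorine and the trifluoromethyl remain unresolved, as neither changes alone in this pair. From the compounds shown here alone, how a carboxylic acid or a dimethylamino group on this phenyl ring would behave also remains open.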